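The source may hold more compounds than are shown below. What is called first, only, known or untested is meant among the compounds shown, and "the series" means these compounds.

Of the compounds shown here, three have been tested in a functional assay on cells (blood, Homo sapiens) for inhibition, read by chemiluminescence, with a stated time of 30 min; a lower number here means a stronger inhibitor, a higher number a weaker inhibitor. Compound 1 `CC1(C)CC(=O)C(C(=S)SCCO)=C(Nc2ccc(Cl)cc2Cl)C1` gives only a limit there, > 100 ug/mL, not a number. Compound 2 `CC1(C)CC(=O)C=C(Nc2ccc(Br)cc2)C1` likewise gives only a limit, > 100 ug/mL. Compound 3 `CC1(C)CC(=O)C(C(=S)SCc2ccccc2)=C(Nc2ccc(Br)cc2)C1` also stands at a limit, > 100 ug/mL, so its inhibition is not resolved. Among the measured compounds shown here, all three results rest at the limit of > 100 ug/mL in this assay, at which 3 of the 3 values shown sit, and no measured step between them can be read. Compound 4 `CC1(C)CC(=O)C(C(=S)SCCO)=C(Nc2ccc(Br)cc2)C1` differs from compound 3 in one place: hydroxymethyl in place of phenyl on a saturated chain carbon bound to a sulfur. Compound 1 carries the same entering group, and in this assay compound 1 again gives only a limit, > 100 ug/mL. Compound 4 is therefore expected to give 150 ug/mL, within 50 ug/mL to 500 ug/mL. The expected step that the limit leaves unreadable from compound 3 to compound 4 means no change beyond the scatter.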

Compound 4, half-maximal inhibitory concentration: > 100 ug/mL
Compound 4 gave a limit, no number; the forecaster's own chance of this, stated with the estimate: 85%; the middle value is on the limit's open side.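

No step among compound 1, compound 2, compound 3 and compound 4 can be read in this assay: the limit of > 100 ug/mL in this assay, at which 4 of the 4 values shown sit.

The compounds shown leave open whether any of these changes in structure alters inhibition at all.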